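Series notes: pyridin-3-yl for phenyl on the ring amine

The source may hold more compounds than are shown below. What is called first, only, known or untested is meant among the compounds shown, and "the series" means these compounds.

For the measured compounds named here, compound 2 `Nc1ccccc1NC(=O)c1ccc(CSC(=S)N2CCN(c3ccccc3)CC2)cc1` stands highest of the two numbers so far in a functional assay on MGC-803 cells (Homo sapiens) for antiproliferative activity, read by CCK-8 assay, with a stated time of 72 h, tested at 8 uM (on this read-out higher numbers stand for a stronger effect at the one concentration tested and lower numbers for a weaker effect), giving 87.4%. Going by the values given here, its nearest neighbour, compound 1 `Nc1ccccc1NC(=O)c1ccc(CSC(=S)N2CCN(Cc3ccccn3)CC2)cc1`, gives 65.2% in this assay, and the only measured step is a number 22.2 percentage points higher from compound 1 to compound 2 (beyond the scatter). Compound 3 `Nc1ccccc1NC(=O)c1ccc(CSC(=S)N2CCN(c3cccnc3)CC2)cc1` differs from compound 2 by pyridin-3-yl in place of phenyl on an amine nitrogen in a ring. Unlike compound 1, compound 3 keeps an aromatic ring directly on the ring amine nitrogen, so the earlier step bears on it only loosely; no step beyond the scatter is expected. Compound 3 is therefore expected to give 80% (range 60% to 92%), an estimated step of a number 7.4 percentage points lower from compound 2 to compound 3 (within the scatter) in this assay.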

Compound 3, a percentage reported as inhibition, at one concentration (the size of the read-out at that concentration, not a potency): 76.9%
For compound 3 the middle estimate is 3.1 percentage points above the measured one; measured number inside the range.
By their numbers in this assay, from the lowest: compound 1; then compound 3; then compound 2.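

In this assay pyridin-3-yl in place of phenyl on the ring amine nitrogen is not a silent change (a number 10.5 percentage points lower from compound 2 to compound 3 (beyond the scatter)), so this position responds to a single ring nitrogen in the aromatic group. Pyridin-3-yl also reads above (pyridin-2-yl)methyl (a number 11.7 percentage points higher from compound 1 to compound 3 (beyond the scatter)), which leaves phenyl highest of the three groups. For the compounds shown here, no evidence on either step is at hand. Open, on these data alone, is how pyridin-4-yl or benzyl on the same amine nitrogen would read, and so how much of the gap to compound 1 belongs to the methylene link and how much to the ring nitrogen.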